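Halogen swap at the meta position of compound 1

The compounds below may be only part of what the source reports. "The series", "measured", "known", "first", "only" and "open" are said of these compounds alone.

Compound 1 `S=C(N/N=C/c1ccc2ccccc2n1)Nc1cccc(Cl)c1` gives 52500 nM in a functional assay on HeLa cells (Homo sapiens) for antiproliferative activity, read by sulforhodamine B assay, with a stated time of 72 h (a higher number here means a weaker inhibitor, a lower number a stronger inhibitor), the highest of the two numbers in hand. Compound 2 `CN(C)C(=S)N/N=C/c1cnc2ccccc2n1` gives 750 nM, a gap beyond the scatter. Compound 3 `Cc1ccc(NC(=O)N/N=C/c2ccc3ccccc3n2)cc1` returns only a limit, > 100000 nM, namely (the limit of > 100000 nM in this assay, at which 1 of the 3 values shown sits). Among the measured compounds shown here, no two measured compounds differ in a single place, so no measured step is available. Compound 4 `S=C(N/N=C/c1ccc2ccccc2n1)Nc1cccc(Br)c1` differs from compound 1 in one way: bromo in place of chloro on an aromatic carbon; cut one bond further out, 3-chlorophenyl becomes 3-bromophenyl. For this change no step beyond the scatter is expected in this assay. Compound 4 is therefore estimated at 45000 nM, between 20000 nM and 100000 nM. The implied step a 1.2-fold lower number from compound 1 to compound 4 (0.07 log units; within the scatter) is expected to sit within the scatter.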

Compound 4, half-maximal inhibitory concentration: 70000 nM
For compound 4 the middle estimate is 1.6-fold (0.19 log units) below the measured one, within the range that was stated.
By their numbers in this assay, from the lowest: compound 2; then compounds 1 and 4 (each within the scatter of the next). At a limit, above all of these: compound 3.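

In this assay the swap of chloro for bromo gives a 1.3-fold higher number from compound 1 to compound 4 (0.12 log units; within the scatter). Among the compounds shown here, this is the first single-place step, and at this position on the carbon-only aromatic ring the two halogens cannot be told apart. Compound 4 therefore adds no separation from compound 1 at this place.

As far as these compounds go, whether an amine, a methoxy group or a carboxylic acid at the same place would move the number beyond the scatter remains open. Compound 3 offers a limit and not a number: the limit of > 100000 nM in this assay, at which 1 of the 4 values shown sits.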